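The source may hold more compounds than are shown below. What is called first, only, known or untested is meant among the compounds shown, and "the series" means these compounds.

Compound 2 `O=c1[nH]c(=O)n([C@@H]2CS[C@@H](CO)O2)cc1Br` is the starting point of this step. In a functional assay on Vero cells (Chlorocebus sabaeus) for inhibition (on this read-out higher numbers stand for weaker inhibition and lower numbers for stronger inhibition), compound 2 gives > 100000 nM, a limit of the assay and not a number. Compound 1 `Nc1nc(O)c2ncn([C@H]3CS[C@@H](CO)O3)c2n1` gives in this assay > 100000 nM, again a limit. Compound 3 `Nc1nc(Cl)c2ncn([C@H]3CS[C@@H](CO)O3)c2n1` gives in this assay > 100000 nM, also a limit. For the measured compounds named here, the only measured step, a step that the two limits leave unreadable from compound 1 to compound 3, is therefore unreadable, and the limit of > 100000 nM in this assay, at which 3 of the 3 values shown sit, sums up the whole series so far. Compound 4 `O=c1[nH]c(=O)n([C@@H]2CS[C@@H](CO)O2)cc1Cl` differs from compound 2 by chloro in place of bromo on an aromatic carbon. Going by the values given here, no measured step covers chloro in place of bromo, so nothing beyond the scatter is expected. For compound 4 in this assay an estimate of 100000 nM, between 30000 nM and 300000 nM, is expected, most probably again as a limit. The step of a number no higher from compound 2 to compound 4 (the limit leaves the size open) is expected to be essentially none.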

Compound 4, half-maximal inhibitory concentration: > 100000 nM
Compound 4: no number, only a limit (the forecaster's own chance of this, stated with the estimate: 85%); the middle value lies on the limit itself.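

Compound 2 and compound 4 each give only a limit, and the step between them, chloro in place of bromo, cannot be read. The compounds shown leave open how bromo and chloro compare in this assay, and whether any compound here gives a number.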